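Moving the Pyridine Attachment Point on Compound 1

The source may hold more compounds than are shown below. What is called first, only, known or untested is meant among the compounds shown, and "the series" means these compounds.

Measured compounds:
compound 1, `CO/C(O)=C1\C(C)=NC(C)=C([N+](=O)[O-])C1c1ccncc1`: 48500 nM
compound 2, `CC1=NC(C)=C([N+](=O)[O-])C(c2ccncc2)/C1=C(\O)OCC(C)C`: 8510 nM

In a functional assay (cardiac atrium) for agonist activity, with Cavia porcellus as the target (on this read-out lower numbers stand for an effect already at smaller amounts and higher numbers for an effect only at larger amounts of compound), compound 1 gives 48500 nM, the highest of the two numbers, and compound 2 gives 8510 nM. Among the measured compounds shown here, the only measured step is a 5.7-fold lower number from compound 1 to compound 2 (0.76 log units; beyond the scatter). Compound 3, `CO/C(O)=C1\C(C)=NC(C)=C([N+](=O)[O-])C1c1cccnc1`, is not yet measured and differs from compound 1 by pyridin-3-yl in place of pyridin-4-yl on a saturated ring carbon. For the measured compounds named here, the measured step concerns isopropyl in place of hydrogen and does not bear on this change; no measured pair separates pyridin-3-yl from pyridin-4-yl. The step of a 1.1-fold lower number from compound 1 to compound 3 (0.03 log units; within the scatter) is therefore expected to stay within the scatter, with wide uncertainty. For compound 3 the estimate is 45000 nM, between 12000 nM and 150000 nM.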

Compound 3, half-maximal effective concentration: 70000 nM
The estimate for compound 3 lay 1.6-fold (0.19 log units) below the measured number; the measured number falls inside the stated range.
By their numbers in this assay, from the lowest: compound 2; then compounds 1 and 3 (each within the scatter of the next).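

In this assay, pyridin-3-yl in place of pyridin-4-yl on the saturated ring carbon gives a 1.4-fold higher number from compound 1 to compound 3 (0.16 log units; within the scatter) and so does not separate the two compounds. Among the compounds shown here, this is the first measured change at this position, where the earlier compounds all carried pyridin-4-yl. The compounds shown leave open whether pyridin-2-yl, phenyl or an aminophenyl group at this carbon would shift the number, and whether pyridin-3-yl would behave the same alongside the isobutyl chain of compound 2. No available evidence accounts for this result.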